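Swapping a propyl for a trifluoromethylphenyl on the triazole

The source may report more compounds than this note shows. Statements on the series, on what has been measured and on what is new or still open speak of the compounds shown alone.

Compound 2 `CCCc1cn(C(c2ccccc2)c2cc3cc(Br)ccc3nc2OC)nn1` gives 0.85% in an ADME assay on HEK293 cells (Homo sapiens) for cytotoxicity, read by sulforhodamine B assay, with a stated time of 48 h, tested at 10 uM (a higher number here means more inhibition at the concentration tested (going by the name of the read-out), a lower number less inhibition), the lowest of the two numbers recorded, with compound 1 `CCOC(=O)c1cn(C(c2ccccc2)c2cc3cc(Br)ccc3nc2OC)nn1` closest at 2%. Among the compounds with values here, the one measured step, a number 1.2 percentage points lower from compound 1 to compound 2 (within the scatter), changes the same position and stays within the scatter. Compound 3 `COc1nc2ccc(Br)cc2cc1C(c1ccccc1)n1cc(-c2ccccc2C(F)(F)F)nn1` differs from compound 2 by 2-(trifluoromethyl)phenyl in place of propyl on an aromatic carbon. Within the data shown here, because the only comparable step a number 1.2 percentage points lower from compound 1 to compound 2 (within the scatter) was within the scatter, no step beyond the scatter is expected for compound 3, so the estimate is a number 4.2 percentage points higher from compound 2 to compound 3 (within the scatter). Compound 3 is expected to give about 5%, within -10% to 25%.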

Compound 3, a percentage reported as inhibition, at one concentration (the size of the read-out at that concentration, not a potency): 14.3%
Estimate against measurement, compound 3: 9.3 percentage points below, within the range that was stated.
By their numbers in this assay, from the lowest: compounds 2 and 1 (each within the scatter of the next); then compound 3.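

A group on this aromatic carbon can move the number beyond the scatter: there is a number 13.5 percentage points higher from compound 2 to compound 3 (beyond the scatter) and a number 12.3 percentage points higher from compound 1 to compound 3 (beyond the scatter) in this assay and so 2-(trifluoromethyl)phenyl stands apart from both propyl and ethoxycarbonyl, though both steps are modest. Nothing measured here says why the number rises. The compounds shown leave open whether the higher number goes with the aromatic ring itself or with its trifluoromethyl, which a plain phenyl at this carbon would separate. As far as these compounds go, how an amine in the same place would read also stays open.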